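Allyl and cyclopropyl amides: whole-organism toxicity notes

A few compounds are considered here, and "the series" means these few. Any claim that something is new, unique, unknown or untested is made for them only; others in the source may bear on it.

Measured so far:
compound 1 `C=CCNC(=O)/C(C)=C(\C)c1ccc(Br)cc1`, 500 mg/kg
compound 2 `C=CCNC(=O)/C(C)=C(/C)c1ccccc1`, 400 mg/kg
compound 3 `C/C(C(=O)NC1CC1)=C(/C)c1ccc(Br)cc1`, 130 mg/kg

All three compounds were run in a toxicity assay on the whole organism (strain Icem-CET (SPF Caw)) for cytotoxicity, with Mus musculus as the target; on this read-out higher numbers stand for an effect only at larger amounts of compound and lower numbers for an effect already at smaller amounts. Compound 1 gives 500 mg/kg and compound 2 gives 400 mg/kg; the two lie within the usual scatter of each other, so no order between them is claimed. Compound 3 stands apart from both: the step of a 3.8-fold lower number from compound 1 to compound 3 (0.59 log units; beyond the scatter) is beyond the scatter, and against compound 2 it also lies beyond the scatter. The change from compound 1 to compound 3 is cyclopropyl in place of allyl on an amide-type nitrogen.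

Compound 2 and compound 1 differ in their cores; the difference between the two cores is not broken down here, and their values in this assay show only that they sit close together.

Compound 4 `C/C(C(=O)NC1CC1)=C(\C)c1ccccc1` has not yet been measured. Going by the values given here, it stands to compound 2 as compound 3 stands to compound 1: the change is cyclopropyl in place of allyl on an amide-type nitrogen, the same change, at the same place, as the one made from compound 1 to compound 3. Among the compounds with values here, only this one example of the change exists among the measured compounds, so the expectation rests on a single step. Applying that step to compound 2, the estimated step for compound 4 is a 3.6-fold lower number from compound 2 to compound 4 (0.56 log units; beyond the scatter). Compound 4 is therefore expected to give about 110 mg/kg in this assay, with a likely range from 60 mg/kg to 220 mg/kg.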

Compound 4, dose for half-maximal effect: 300 mg/kg
Compound 4: the middle estimate sits 2.7-fold (0.44 log units) below what was measured; measured number outside the range, above it.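

In this assay cyclopropyl in place of allyl on an amide-type nitrogen gives a 1.3-fold lower number from compound 2 to compound 4 (0.12 log units; within the scatter) and so moves the number by no more than the usual scatter on the core of compound 2. The size of the step therefore does not carry over unchanged between the two cores, and the step on the core of compound 1 is no safe guide to the step on the core of compound 2: the same change on two cores in this assay, a 3.8-fold lower number (0.59 log units; beyond the scatter) from compound 1 to compound 3 and a 1.3-fold lower number (0.12 log units; within the scatter) from compound 2 to compound 4, 2.9-fold (0.46 log units) apart, beyond the scatter of two such steps.

This comparison rests on one pair for each core, so it shows that the outcome of the change differs between these two cores, but not which feature of the cores accounts for the difference or how the change would behave on any third core.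

The compounds shown leave open whether the dependence on the core is specific to allyl and cyclopropyl or also appears with other groups on the amide-type nitrogen, such as propyl or cyclobutyl. They also leave open where the step would fall on a core carrying chlorine or a methoxy group, which would show whether the smaller or the larger step is the more usual one in this series.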